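Changing one phenyl group on the lowest-ranked compound

The source may hold more compounds than are shown below. What is called first, only, known or untested is meant among the compounds shown, and "the series" means these compounds.

So far three related compounds have been measured in a physicochemical assay for solubility, measured as kinetic solubility, at pH 6.5 (a higher number here means a more soluble compound, a lower number a less soluble compound), and their values spread widely. Compound 1 (`C[C@@H](c1c[nH]c2ncccc12)c1nnc2ccc(-c3cnn(C)c3)nn12`) reaches 150000 nM and compound 2 (`Nc1ccc2nnc(Cc3ccc4ncccc4c3)n2n1`) reaches 453000 nM in the same measurement. Compound 3 (`COc1ccc(-c2ccc3nnc([C@@H](C)c4ccc5ncccc5c4)n3n2)cc1C`) stands lowest at 1770 nM and lies beyond the usual scatter from both of the others.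

Compound 4 (`CNC(=O)c1ccc(-c2ccc3nnc([C@@H](C)c4ccc5ncccc5c4)n3n2)cc1`) has yet to be measured. It differs from compound 3 in one place, where 4-(methylcarbamoyl)phenyl replaces 4-methoxy-3-methylphenyl on an aromatic carbon (4-(methylcarbamoyl)phenyl in place of 4-methoxy-3-methylphenyl on an aromatic carbon) while the rest of the structure stays the same.

Among the measured compounds shown here, no measured pair shows this change on its own, so any expectation here is rough. Compound 3 is the lowest of the three at 1770 nM and this leaves more room for a rise than for a fall. In this assay the expected step is a modest rise, estimated as a 3.4-fold higher number from compound 3 to compound 4 (0.53 log units; beyond the scatter) and it may not clear the scatter. For compound 4 the estimated value is 6000 nM with an expected range from 1500 nM to 30000 nM in repeated measurements.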

Compound 4, solubility: 11000 nM
Estimate against measurement, compound 4: 1.8-fold (0.26 log units) below; measured number inside the range.
By their numbers in this assay, from the lowest: compound 3; then compound 4; then compound 1; then compound 2.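

In this assay the group on the aromatic carbon next to the ring nitrogen of the shared core proves able to move the number: 4-(methylcarbamoyl)phenyl in place of 4-methoxy-3-methylphenyl gives a 6.2-fold higher number from compound 3 to compound 4 (0.79 log units; beyond the scatter) with the rest of the structure unchanged. Among the compounds shown here, this is the first comparison that isolates a single place, and the swap keeps the carbon-only aromatic ring and the hydrogen-bond acceptor count while adding one hydrogen-bond donor. No measurement shown here explains the step.

The methoxy, the ring methyl and the methylcarbamoyl group all change together, so this one step cannot separate their shares. Also open, as far as these compounds go, is where a carboxylic acid or a morpholine on the same phenyl ring would fall in this assay relative to these two compounds.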